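Extending the dimethylamino substituent by one carbon on the fused core

The source may hold more compounds than are shown below. What is called first, only, known or untested is meant among the compounds shown, and "the series" means these compounds.

Compound 3 `CN(C)c1c(F)c(N)c2c(=O)cc(-c3ccc(N)c(F)c3)oc2c1F`: 39 nM
Compound 2 `Nc1ccc(-c2cc(=O)c3c(N)c(F)c(CO)c(F)c3o2)cc1F`: 62 nM
Compound 1 `COc1c(F)c(N)c2c(=O)cc(-c3ccc(N)c(F)c3)oc2c1F`: 100 nM

In a functional assay on MCF7 cells (Homo sapiens) for cytotoxicity, read by neutral red uptake, with a stated time of 3 days (a lower number here means a stronger inhibitor, a higher number a weaker inhibitor), compound 3 gives the lowest of the three numbers; its gap to compound 2 lies within the scatter, while compound 1 sits beyond it. Compound 4 `CN(C)Cc1c(F)c(N)c2c(=O)cc(-c3ccc(N)c(F)c3)oc2c1F` differs from compound 3 by (dimethylamino)methyl in place of dimethylamino on an aromatic carbon. Within the data shown here, the closest precedent is a 1.6-fold lower number from compound 1 to compound 2 (0.21 log units; within the scatter), where a one-carbon spacer was likewise inserted between the ring and the heteroatom group and the change stayed within the scatter. The steps of a 2.6-fold lower number from compound 1 to compound 3 (0.41 log units; beyond the scatter) and a 1.6-fold lower number from compound 2 to compound 3 (0.20 log units; within the scatter) show that this position tolerates varied groups with at most modest effect. Compound 4 is therefore expected to stay close to compound 3, with a step of a 1.2-fold higher number from compound 3 to compound 4 (0.09 log units; within the scatter) that is not expected to exceed the scatter. For compound 4 the estimate is 48 nM, with a range from 22 nM to 105 nM.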

Compound 4, half-maximal inhibitory concentration: 72 nM
For compound 4 the middle estimate is 1.5-fold (0.18 log units) below the measured one; low and high end bracket the measured number.
By their numbers in this assay, from the lowest: compounds 3, 2, 4 and 1 (each within the scatter of the next, the first and the last beyond it).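

In this assay the one-carbon extension gives a 1.8-fold higher number from compound 3 to compound 4 (0.27 log units; within the scatter) and so cannot be told apart from repeat measurement. Compound 4 also lies within the scatter of the hydroxymethyl and methoxy compounds, with a 1.2-fold higher number from compound 2 to compound 4 (0.06 log units; within the scatter) and a 1.4-fold lower number from compound 1 to compound 4 (0.14 log units; within the scatter) as its steps. Among these compounds, compound 3 thus remains the only compound here beyond the scatter from compound 1, and the added carbon removes that separation.

Going by these compounds, whether a longer chain such as (dimethylamino)ethyl or a cyclic amine such as morpholine would stay in this narrow band remains open. No measurement shown bears on the cause of these steps.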